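This account rests on a few compounds, and the source may have more. Where it says the series, first, only, none or still open, it means among the compounds named here.

Measured in an ADME assay on S9 fraction from liver (Rattus norvegicus, strain Wistar) for metabolic stability, tested at 0.1 uM; a lower number here means slower removal, a higher number faster removal of the compound:
- compound 1 `CCN(CC)c1cc(OCc2cc(F)c(Oc3ccc(Cl)c(C(F)(F)F)c3)c(F)c2)nc(=O)n1C` gives 41.9 mL/min/kg
- compound 2 `CN1CCN(c2cc(OCc3cc(F)c(Oc4ccc(Cl)c(C(F)(F)F)c4)c(F)c3)nc(=O)n2C)CC1` gives 1140 mL/min/kg

Compound 2 has the higher of these two numbers, and by a wide margin. Compound 3 `COC1CCN(c2cc(OCc3cc(F)c(Oc4ccc(Cl)c(C(F)(F)F)c4)c(F)c3)nc(=O)n2C)CC1` remains to be measured. It carries 4-methoxypiperidin-1-yl in place of 4-methylpiperazin-1-yl on an aromatic carbon and is otherwise unchanged. Among the compounds with values here, only one measured step bears on this change, and it is large and beyond the scatter: a 27-fold higher number from compound 1 to compound 2 (1.43 log units; beyond the scatter), with 4-methylpiperazin-1-yl replacing diethylamino at the same place. Within the data shown here, no measured compound holds the 4-methoxypiperidin-1-yl group, so the evidence is thin. Compound 2 is the compound that rose in that step, so a clearly lower number is expected in this assay, though probably not the full way back to compound 1. The expected change is a 5.7-fold lower number from compound 2 to compound 3 (0.76 log units; beyond the scatter). For compound 3 the estimated clearance is 200 mL/min/kg (50 mL/min/kg to 800 mL/min/kg).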

Compound 3, clearance: 184 mL/min/kg
Estimate against measurement, compound 3: 1.1-fold (0.04 log units) above, and the stated range covers the measured number.
By their numbers in this assay, from the lowest: compound 1; then compound 3; then compound 2.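

In this assay, 4-methoxypiperidin-1-yl in place of 4-methylpiperazin-1-yl gives a 6.2-fold lower number from compound 2 to compound 3 (0.79 log units; beyond the scatter), so a high number at this place does not follow from a six-membered non-aromatic ring as such. The ring does not take the number all the way back either: diethylamino remains the lowest of the three groups, and the change between the two groups gives a 4.4-fold higher number from compound 1 to compound 3 (0.64 log units; beyond the scatter), which leaves compound 3 between compound 1 and compound 2. No measurement offered here accounts for either step.

From the compounds shown here alone, the two rings differ at a single ring atom and in what it carries, so it stays open whether plain piperidine, morpholine or 4-hydroxypiperidine would stand nearer to compound 3 or to compound 2. Going by these compounds, it is also open whether pyrrolidine or an open-chain amine such as dipropylamino would reach a number as low as that of compound 1.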